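The compounds below may be only part of what the source reports. "The series", "measured", "known", "first", "only" and "open" are said of these compounds alone.

Measured compounds, cytotoxicity read-out in an ADME assay on RAW264.7 cells (Mus musculus) for cytotoxicity, with a stated time of 24 h; on this read-out higher numbers stand for weaker inhibition and lower numbers for stronger inhibition (all three reported only as a limit):
compound 1, `COc1ccc(-c2cc(-c3ccc4c(c3)CCCC4)[nH]c(=O)c2C#N)cc1OC`: > 100000 nM
compound 2, `CC(C)c1ccc(-c2cc(-c3ccc4c(c3)CCCC4)[nH]c(=O)c2C#N)cc1`: > 100000 nM
compound 3, `CC(C)c1ccc(-c2cc(-c3ccc4c(c3)CCCC4)[nH]c(=S)c2C#N)cc1`: > 100000 nM

Compound 3 stands nowhere on a numerical scale in this assay: its value is a limit of the assay, not a number. The two other values shown are limits as well, so nothing in these data ranks the three compounds against each other; all sit at the limit of > 100000 nM in this assay, at which 3 of the 3 values shown sit.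

Compound 4 is `N#Cc1c(-c2c[nH]c3ccccc23)cc(-c2ccc3c(c2)CCCC3)[nH]c1=S`. It differs from compound 3 by 1H-indol-3-yl in place of 4-isopropylphenyl on an aromatic carbon of the shared core, ortho to a cyano group and opposite the ring nitrogen.

For the measured compounds named here, no step between measured compounds exists here, and with every value at the limit no direction can be read from them. The expectation for this change in this assay is therefore no step beyond the scatter, and most probably again only a limit. The estimate for compound 4 is 100000 nM, with a range from 40000 nM to 300000 nM. The expected step is a number no higher from compound 3 to compound 4 (the limit leaves the size open).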

Compound 4, half-maximal inhibitory concentration: > 100000 nM
Compound 4 was reported as a limit; the forecaster's own chance of this, stated with the estimate: 80%; the middle value sits exactly at the limit.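

In this assay compound 4 gives > 100000 nM, a limit of the assay and not a number, so no step can be read between compound 3 and compound 4: the limit of > 100000 nM in this assay, at which 4 of the 4 values shown sit.

The compounds shown leave open how they rank against each other in this assay, and whether 1H-indol-3-yl in place of 4-isopropylphenyl changes the read-out at all.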